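This account rests on a few compounds, and the source may have more. Where it says the series, first, only, none or still open, it means among the compounds named here.

In a functional assay on UO-31 cells (Homo sapiens) for inhibition, read by sulforhodamine B assay, with a stated time of 48 h, tested at 10 uM (on this read-out higher numbers stand for more inhibition at the one concentration tested (going by the name of the read-out) and lower numbers for less inhibition), the three measured compounds gave:

Compound 1 `Brc1cn2ccnc2c(-c2ccc3ncn(C4CCCCC4)c3c2)n1`: 37.6%
Compound 2 `c1cn2cc(-c3ccsc3)nc(-c3ccc4ncn(C5CCCCC5)c4c3)c2n1`: 23.1%
Compound 3 `CC(=O)c1ccc(-c2cn3ccnc3c(-c3ccc4ncn(C5CCCCC5)c4c3)n2)cc1`: 23.1%

Compound 3 stands level with compound 2 at the digits shown, and the two together are the lowest of the three numbers; compound 1 lies higher, as the step of a number 14.5 percentage points lower from compound 1 to compound 3 (beyond the scatter) shows. Compound 4 `COc1ccccc1-c1cn2ccnc2c(-c2ccc3ncn(C4CCCCC4)c3c2)n1` differs from compound 3 in one place: 2-methoxyphenyl in place of 4-acetylphenyl on an aromatic carbon. The step that bears most directly on this is no change at the digits printed from compound 2 to compound 3 (within the scatter), an exchange of one ring group for another at the same place, which stayed within the scatter. The steps of a number 14.5 percentage points lower from compound 1 to compound 2 (beyond the scatter) and a number 14.5 percentage points lower from compound 1 to compound 3 (beyond the scatter) were modest and both ran downward. Going by the values given here, no measured step exchanges one six-membered ring of carbon only for another. Compound 4 is therefore expected to stay close to compound 3, with a step of a number 1.9 percentage points higher from compound 3 to compound 4 (within the scatter). The estimate for compound 4 is 25%, with a range from 12% to 40%.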

Compound 4, a percentage reported as inhibition, at one concentration (the size of the read-out at that concentration, not a potency): 24%
Beside the measured number, compound 4's estimate is 1 percentage points above it; measured number inside the range.
By their numbers in this assay, from the lowest: compounds 2, 3 and 4 (each within the scatter of the next); then compound 1.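

In this assay the exchange of 4-acetylphenyl for 2-methoxyphenyl, the first here between two six-membered aromatic rings of carbon only, gave a number 0.9 percentage points higher from compound 3 to compound 4 (within the scatter) and so left the number in place. The steps of a number 0.9 percentage points higher from compound 2 to compound 4 (within the scatter) and a number 13.6 percentage points lower from compound 1 to compound 4 (beyond the scatter) show that all three ring-bearing compounds now stand within the scatter of one another and apart from the bromo compound. Nothing available explains why these ring groups read alike.

As far as these compounds go, whether an amine, a carboxylic acid or a longer alkyl chain at this position would leave this level remains open. So does whether the same level would hold at other concentrations.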